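Adding an Amino Group to Compound 2

A few compounds are considered here, and "the series" means these few. Any claim that something is new, unique, unknown or untested is made for them only; others in the source may bear on it.

Of the compounds shown here, three have been measured in a functional assay on DU-145 cells (Homo sapiens) for cytotoxicity, read by trypan blue exclusion, with a stated time of 96 h; on this read-out lower numbers stand for stronger inhibition and higher numbers for weaker inhibition. Compound 1 (`COc1ccc(NS(=O)(=O)/C=C/c2ccccc2OC)cc1`) gives 5000 nM, and compound 3 (`COc1ccc(/C=C/S(=O)(=O)Nc2c(OC)cc(OC)cc2OC)cc1`) gives 7500 nM. Compound 2 (`COc1ccc(NS(=O)(=O)/C=C/c2cc(OC)c(OC)c(OC)c2)cc1`) gives 35000 nM, the highest number of the three and so the weakest, beyond the usual scatter from both others. Compound 4 (`COc1ccc(NS(=O)(=O)/C=C/c2cc(OC)c(OC)c(OC)c2)cc1N`) turns the 4-methoxyphenyl of compound 2 into 3-amino-4-methoxyphenyl: amino in place of hydrogen on an aromatic carbon. Within the data shown here, no measured pair shows this change, so any expectation is loose. With compound 2 at 35000 nM, there is room to fall, and a step to lower numbers in this assay, beyond the scatter, is expected. The estimated change is an 8.8-fold lower number from compound 2 to compound 4 (0.94 log units; beyond the scatter). For compound 4 the expected value is 4000 nM, within a range from 400 nM to 30000 nM.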

Compound 4, half-maximal inhibitory concentration: 35000 nM
Compound 4: the middle estimate sits 8.8-fold (0.94 log units) below what was measured; the measured number lies above the stated range.
By their numbers in this assay, from the lowest: compounds 1 and 3 (each within the scatter of the next); then compounds 2 and 4 (each within the scatter of the next).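

In this assay, amino in place of hydrogen on this aromatic carbon, ortho to a methoxy group, gives no change at the digits printed from compound 2 to compound 4 (within the scatter). Among these compounds, this is the first direct reading of a change at this position, and on the core of compound 2 the added amino leaves the number where it was. Nothing available explains this flat result.

As far as these compounds go, it remains open whether a different group at this position, such as a hydroxyl, a nitro or an acetamide, would move the number. From the compounds shown here alone, it is also open whether the same amino would matter on compound 1, which starts from a lower number.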